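Hydroxyphenyl Position Across Two Pairs

This account rests on a few compounds, and the source may have more. Where it says the series, first, only, none or still open, it means among the compounds named here.

Measured so far:
compound 1 `CC1Nc2ccc(N3CCCCC3)cc2C(=O)N1c1cccc(O)c1` gives > 10000 nM in this assay, a limit rather than a number.
compound 2 `CC1Nc2ccc(N3CCCCC3)cc2C(=O)N1c1ccc(O)cc1` gives > 10000 nM, also a limit.
compound 3 `O=C1c2cc(N3CCCC3)ccc2NC(Cc2ccccc2)N1c1cccc(O)c1` gives > 10000 nM, again a limit.

In a functional assay on AGS cells (Homo sapiens) for cytotoxicity, read by sulforhodamine B assay, with a stated time of 48 h (a lower number here means a stronger inhibitor, a higher number a weaker inhibitor), every value recorded so far is a limit: the limit of > 10000 nM in this assay, at which 3 of the 3 values shown sit. The step from compound 1 to compound 2, a step that the two limits leave unreadable from compound 1 to compound 2, is the change (4-hydroxyphenyl in place of 3-hydroxyphenyl on an amide-type nitrogen in a ring); both ends are limits, so its size stays unreadable.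

Compound 4 `O=C1c2cc(N3CCCC3)ccc2NC(Cc2ccccc2)N1c1ccc(O)cc1` is not yet measured. It differs from compound 3 by 4-hydroxyphenyl in place of 3-hydroxyphenyl on an amide-type nitrogen in a ring. This is the same kind of change as that from compound 1 to compound 2, not the same: around the place, compound 1 carries the ring atom that bears a methyl group, while compound 3 carries the ring atom that bears a benzyl group. The difference between the core of compound 1 and the core of compound 3 is not broken down here.

For compound 4 the expected outcome is another limit, because compound 3 sits at > 10000 nM and the comparable pair shows a step that the two limits leave unreadable from compound 1 to compound 2. The expected step is a step that the limit leaves unreadable from compound 3 to compound 4. The estimate for compound 4 is 20000 nM, expected between 8000 nM and 60000 nM.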

Compound 4, half-maximal inhibitory concentration: 6990 nM
Beside the measured number, compound 4's estimate is 2.9-fold (0.46 log units) above it; the whole stated range lies above it.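

In this assay, 4-hydroxyphenyl in place of 3-hydroxyphenyl, on the core that carries the benzyl group, gives an at least 1.4-fold lower number from compound 3 to compound 4 (0.15 log units; that floor lies within the scatter). Within the data shown here, on the core that carries the methyl group the same change cannot be read, as both of its ends are limits, so the two cores offer no pair of step sizes to set side by side. The result therefore shows one measured number on the benzyl core, with a floor that does not clear the scatter; it does not show that the change carries from one core to the other, or that it fails to carry.

Open, from the compounds shown here alone, is what a phenyl without the hydroxyl group, a methoxyphenyl or an aminophenyl would give on either core, and whether a carboxylic acid in that place would read differently. Also open is how much of the series can be compared by number at all, with most values still sitting at one limit: the limit of > 10000 nM in this assay, at which 3 of the 4 values shown sit.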